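Furan-to-imidazole swap on a weak antiproliferative series

A few compounds are considered here, and "the series" means these few. Any claim that something is new, unique, unknown or untested is made for them only; others in the source may bear on it.

Three related compounds have been examined in a functional assay on CWR22R cells (Homo sapiens) for antiproliferative activity, read by CCK-8 assay, with a stated time of 6 days; on this read-out lower numbers stand for stronger inhibition and higher numbers for weaker inhibition. Compound 1 `N#Cc1ccc(N2CCCc3c(-c4cccnc4)cccc32)cc1C(F)(F)F` gives 12300 nM in this assay. For compound 3 `CCN(c1cccc(-c2ccccc2)c1)c1ccc(C#N)c(Cl)c1` no result was reported, its entry in this assay being "not determined" (no result reported). Compound 2 `CCN(c1ccc(C#N)c(Cl)c1)c1cc(-c2ccoc2)ccc1C` reaches only a limit of this assay, > 30000 nM, and thus stands at the limit of > 30000 nM in this assay, at which 1 of the 3 values shown sits; it holds no single number. The next compound, compound 4 `CCN(c1ccc(C#N)c(Cl)c1)c1cc(-n2ccnc2)ccc1C`, differs from compound 2 by 1H-imidazol-1-yl in place of furan-3-yl on an aromatic carbon. For the measured compounds named here, no measured pair differing in one place is available to calibrate a step of this kind, so no direction can be drawn from the data. The estimated step from compound 2 to compound 4 is a number no higher from compound 2 to compound 4 (the limit leaves the size open), within scatter. Compound 4 is expected near 30000 nM, between 10000 nM and 90000 nM.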

Compound 4, half-maximal inhibitory concentration: > 30000 nM
Compound 4: no number, only a limit; the forecaster's own chance of this, stated with the estimate: 60%; the middle value sits exactly at the limit.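

In this assay, for the compounds shown here, compound 2 and compound 4 both stand at a limit, so no step between them can be read: the limit of > 30000 nM in this assay, at which 2 of the 4 values shown sit. Going by these compounds, whether 1H-imidazol-1-yl in place of furan-3-yl changes activity at all stays open.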